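Compound 3: dimethylcarbamoyl on the shared core

A few compounds are considered here, and "the series" means these few. Any claim that something is new, unique, unknown or untested is made for them only; others in the source may bear on it.

In a functional assay on SW480 cells (Homo sapiens) for antiproliferative activity, read by MTT assay, with a stated time of 48 h (on this read-out higher numbers stand for weaker inhibition and lower numbers for stronger inhibition), compound 1 `CC(C)=CCC[C@]1(C)/C=C/[C@@H](OC(=O)C=C(C)C)[C@](C)(O)/C=C/C(=O)/C(CN2CCN(C)CC2)=C\C1` gives 800 nM and compound 2 `CC(C)=CCC[C@]1(C)/C=C/[C@@H](OC(=O)C=C(C)C)[C@](C)(O)/C=C/C(=O)/C(Cn2cc(CO)nn2)=C\C1` gives 2870 nM, the higher of the two numbers, which makes compound 2 the weaker inhibitor of this pair. Within the data shown here, the one measured step, a 3.6-fold higher number from compound 1 to compound 2 (0.55 log units; beyond the scatter), is modest but beyond the scatter. It puts 4-(hydroxymethyl)-1H-1,2,3-triazol-1-yl in place of 4-methylpiperazin-1-yl on a saturated chain carbon bound to a double-bonded ring carbon.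

Next in the series is compound 3 `CC(C)=CCC[C@]1(C)/C=C/[C@@H](OC(=O)C=C(C)C)[C@](C)(O)/C=C/C(=O)/C(C(=O)N(C)C)=C\C1`, with the change dimethylcarbamoyl in place of (4-(hydroxymethyl)-1H-1,2,3-triazol-1-yl)methyl on a double-bonded ring carbon. Among the measured compounds shown here, no measured compound carries dimethylcarbamoyl, and a single step is thin evidence. Starting from compound 2 at 2870 nM, the only guide is a step of modest size, so no shift beyond the scatter is expected in this assay, and neither direction is favoured. The expected step is a 1.1-fold lower number from compound 2 to compound 3 (0.06 log units; within the scatter), which is estimated to stay within the scatter. For compound 3 the estimated value is 2500 nM, with an expected range of 800 nM to 8000 nM.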

Compound 3, half-maximal inhibitory concentration: 3300 nM
Estimate against measurement, compound 3: 1.3-fold (0.12 log units) below, and the stated range covers the measured number.
By their numbers in this assay, from the lowest: compound 1; then compounds 2 and 3 (each within the scatter of the next).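

In this assay, (4-(hydroxymethyl)-1H-1,2,3-triazol-1-yl)methyl and dimethylcarbamoyl on the double-bonded ring carbon are not told apart (a 1.1-fold higher number from compound 2 to compound 3 (0.06 log units; within the scatter)), although the exchange removes the five-membered aromatic ring and the hydroxy group and leaves no saturated chain carbon on that ring carbon. Against (4-methylpiperazin-1-yl)methyl, dimethylcarbamoyl gives a step of the same modest class as the triazole (a 4.1-fold higher number from compound 1 to compound 3 (0.62 log units; beyond the scatter)), so among these compounds compound 1 stands alone with the lowest number, while compound 2 and compound 3 form one level. No measurement is available that explains this separation or the lack of a difference between compound 2 and compound 3.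

Open, as far as these compounds go, is whether the lower number of compound 1 depends on the 4-methylpiperazin-1-yl ring as a whole or would also appear with a simpler dimethylaminomethyl or morpholin-4-ylmethyl group on the same ring carbon. Also open, from the compounds shown here alone, is where a carboxylic acid on that carbon, or a dimethylcarbamoyl group carried on a saturated chain carbon, would fall relative to these levels.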